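Working notes: aryl against alkyl on the amine carbon

A few compounds are considered here, and "the series" means these few. Any claim that something is new, unique, unknown or untested is made for them only; others in the source may bear on it.

Measured compounds:
compound 1: `CCCCCCN1CCC(C(=O)Nc2cc(Cl)c(N)cc2OC)CC1`, > 10 mg/kg
compound 2: `COc1cc(N)c(Cl)cc1NC(=O)C1CCN(Cc2cccc(C)c2)CC1`, 2.4 mg/kg
compound 3: `COc1cc(N)c(Cl)cc1NC(=O)C1CCN(CC2CCC2)CC1`, > 10 mg/kg

In a functional assay on the whole organism for antagonist activity, with Mus musculus as the target (a higher number here means that more compound is needed for the effect, a lower number that less compound is needed), compound 1 gives > 10 mg/kg, which is a limit of the assay and not a number. Compound 3 likewise gives > 10 mg/kg, again a limit. Within the data shown here, compound 2 gives 2.4 mg/kg, the only number in the set; the two other values sit at the limit of > 10 mg/kg in this assay, at which 2 of the 3 values shown sit. The measured steps are an at least 4.1-fold lower number from compound 1 to compound 2 (0.61 log units; beyond the scatter) and an at least 4.1-fold higher number from compound 2 to compound 3 (0.61 log units; beyond the scatter), both beyond the scatter, while a step that the two limits leave unreadable from compound 1 to compound 3.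

Compound 4 is `CCOc1ccc(CN2CCC(C(=O)Nc3cc(Cl)c(N)cc3OC)CC2)cc1`. Against compound 2 the change is 4-ethoxyphenyl in place of 3-methylphenyl on a saturated chain carbon bound to an amine nitrogen in a ring. The two steps that touch compound 2 each exchange the aromatic group for a saturated one, and each cost at least a modest amount; neither compares one aromatic group with another, so they bear on compound 4 only by keeping the aromatic ring in place. Among the measured compounds shown here, no measured step tells how the 4-ethoxyphenyl itself compares with the 3-methylphenyl. The expectation is therefore a step within the scatter, a 1.3-fold higher number from compound 2 to compound 4 (0.10 log units; within the scatter), with a wide range to allow for the unmeasured substituent change. Compound 4 is estimated at 3 mg/kg in this assay, between 1 mg/kg and 10 mg/kg.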

Compound 4, dose for half-maximal effect: 6.3 mg/kg
Compound 4: middle estimate off by 2.1-fold (0.32 log units), on the low side; measured number inside the range.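

In this assay, the two aromatic groups on the saturated chain carbon bound to an amine nitrogen in a ring are not interchangeable: replacing 3-methylphenyl with 4-ethoxyphenyl gives a 2.6-fold higher number from compound 2 to compound 4 (0.42 log units; beyond the scatter), so the aromatic ring alone does not fix the value at this position. Against the saturated groups, 4-ethoxyphenyl gives an at least 1.5-fold lower number from compound 3 to compound 4 (0.20 log units; that floor lies within the scatter) and an at least 1.5-fold lower number from compound 1 to compound 4 (0.20 log units; that floor lies within the scatter), and both floors are too small to show a gain for this aromatic group over cyclobutyl or pentyl. Compound 1 and compound 3 each stand at a limit and not at a number, which leaves the full size of these two steps unread: the limit of > 10 mg/kg in this assay, at which 2 of the 4 values shown sit.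

A 4-methylphenyl or a 3-ethoxyphenyl group at this position would show whether the step from 3-methylphenyl follows the ethoxy group itself or the place of the substituent on the ring. An unsubstituted phenyl group would give the reference for both substituents, and a pyridine ring would test whether a ring of carbon only is needed here.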